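A few compounds are considered here, and "the series" means these few. Any claim that something is new, unique, unknown or untested is made for them only; others in the source may bear on it.

Working notes on the series.

The series shares a core in which a saturated chain carbon bound to two aromatic carbons carries a branched chain. Compound 1 `COc1cc(C(c2ccc(O)c(OC)c2)[C@@H](C)[C@@H](C)CF)ccc1O` gives 38000 nM in a functional assay on HL-60 cells (Homo sapiens) for cytotoxicity, read by WST assay, with a stated time of 48 h; on this read-out higher numbers stand for weaker inhibition and lower numbers for stronger inhibition. Among the measured compounds shown here, compound 3 `COc1cc(C(c2ccc(O)c(OC)c2)[C@H](CC(C)C)C(C)C)ccc1O` gives 9600 nM in the same assay, and the change a 4.0-fold lower number from compound 1 to compound 3 (0.60 log units; beyond the scatter) is the only measured step in the set. Compound 2 `COc1ccc(C(c2ccc(OC)c(OC)c2)[C@@H](C)[C@H](C)CO)cc1OC` reaches only a limit of the assay, > 100000 nM, in this assay; it stands at the limit of > 100000 nM in this assay, at which 1 of the 3 values shown sits, and no number is known for it.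

Compound 4 `COc1ccc(C(c2ccc(OC)c(OC)c2)[C@H](C)[C@@H](C)CO)cc1OC` has not yet been measured. It differs from compound 2 in the following way: the two compounds have the same atoms and bonds and differ only in configuration as drawn: 2 of 2 stereo elements differ (all stereocentres are inverted: mirror images); a stereocentre at a saturated chain carbon is drawn R in compound 2 and S in compound 4; a stereocentre at a saturated chain carbon is drawn S in compound 2 and R in compound 4.

For the measured compounds named here, no measured step concerns an inversion of configuration; the step from compound 1 to compound 3 changes the branched chain and does not bear on a mirror image. Going by the values given here, the only direct anchor is compound 2 itself, which gave a limit. Because compound 2 sits at the limit of > 100000 nM in this assay, at which 1 of the 3 values shown sits, the expectation for compound 4 rests on the same scaffold and substitution, and a large move is not expected. Compound 4 is therefore estimated at 90000 nM, with a range from 20000 nM to 300000 nM, and the expected step of an at least 1.1-fold lower number from compound 2 to compound 4 (0.04 log units; that floor lies within the scatter) is small, with a real chance that only a limit is again reported.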

Compound 4, half-maximal inhibitory concentration: 47000 nM
The estimate for compound 4 lay 1.9-fold (0.28 log units) above the measured number, and the stated range covers the measured number.
By their numbers in this assay, from the lowest: compound 3; then compounds 1 and 4 (each within the scatter of the next). At a limit, above all of these: compound 2.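

Among the compounds shown here, the mirror-image pair is not equivalent on this read-out: in this assay the series now holds an at least 2.1-fold lower number from compound 2 to compound 4 (0.32 log units; beyond the scatter), the first measured step that concerns configuration rather than the branched chain. Configuration alone accounts for this step, because the pair shares all atoms and bonds: the fact that compounds 2 and 4 differ only in the configuration as drawn. The step gives a floor and not a full size, because compound 2 stands at a limit of the assay and has no number: the limit of > 100000 nM in this assay, at which 1 of the 4 values shown sits.

On these data alone, it remains open which of the two inverted stereocentres carries the step, or whether both contribute, and whether the same inversion would shift the number on the core of compound 1. Also open, as far as these compounds go, is how the number in this assay would respond if an amine or a carboxylic acid took the place of the hydroxyl group on the chain of compound 4.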